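Chloro Substitution on the Shared Core: Compound 2 to Compound 3

The source may report more compounds than this note shows. Statements on the series, on what has been measured and on what is new or still open speak of the compounds shown alone.

Measured so far:
compound 1, `Clc1ncc(O[C@@H]2CCNC2)cc1-c1ccccc1`, 75 nM in an assay on a protein complex for binding affinity to Neuronal acetylcholine receptor; alpha4/beta2 (Rattus norvegicus); a lower number here means a stronger inhibitor, a higher number a weaker inhibitor
compound 2, `COc1cccc(-c2cncc(O[C@@H]3CCNC3)c2)c1`, 1120 nM in this assay

Compound 2 holds the higher of the two numbers. Among the measured compounds shown here, its value in this assay stands well apart from that of compound 1, and the two compounds differ in more than one place, so the pair gives no single step to lean on.

Compound 3, `COc1cccc(-c2cc(O[C@@H]3CCNC3)cnc2Cl)c1`, is not yet measured. It differs from compound 2 in one place: chloro in place of hydrogen on an aromatic carbon. Compound 1 carries the same chloro group on the same carbon of the shared core and gives 75 nM, which is the only hint available.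

The expectation for compound 3 is a move toward a lower number, with the step from compound 2 to compound 3 estimated at a 5.6-fold lower number from compound 2 to compound 3 (0.75 log units; beyond the scatter), beyond the scatter. The estimate for compound 3 in this assay is 200 nM, within 50 nM to 800 nM.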

Compound 3, half-maximal inhibitory concentration: 58 nM
The estimate for compound 3 lay 3.4-fold (0.54 log units) above the measured number; the range from low to high includes it.
By their numbers in this assay, from the lowest: compounds 3 and 1 (each within the scatter of the next); then compound 2.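

In this assay, among the compounds shown here, chloro in place of hydrogen on the aromatic carbon next to the ring nitrogen gives a 19-fold lower number from compound 2 to compound 3 (1.29 log units; beyond the scatter), the first single-place step, and it shows that this position strongly affects the number when the methoxy group is present. With chloro at this position, adding the methoxy group gives a 1.3-fold lower number from compound 1 to compound 3 (0.11 log units; within the scatter), which leaves compound 1 and compound 3 within the scatter of each other. Nothing at hand explains the size of the chloro step.

Going by these compounds, whether this step is particular to chloro stays open; bromo, methyl or a nitrile on the same carbon would test that. Also open, on these data alone, is how methoxy behaves on the shared core with hydrogen at this position.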